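Cyclopentyl for cyclobutyl: the solubility to expect

A few compounds are considered here, and "the series" means these few. Any claim that something is new, unique, unknown or untested is made for them only; others in the source may bear on it.

Of the compounds shown here, three sharing one core have been measured in a physicochemical assay for solubility, in phosphate buffer, with a stated time of 18 h; a lower number here means a less soluble compound, a higher number a more soluble compound. Compound 1 (`Cc1ncc2c(N)c(C#N)c(N)nc2n1`), which carries methyl, gives 783000 nM. Compound 2 (`CC(C)c1ncc2c(N)c(C#N)c(N)nc2n1`), which carries isopropyl, reports only a limit, > 1000000 nM, and not a number. Compound 3 (`N#Cc1c(N)nc2nc(C3CCC3)ncc2c1N`), which carries cyclobutyl, gives 217000 nM, the lower of the two actual numbers.

The next compound is compound 4 (`N#Cc1c(N)nc2nc(C3CCCC3)ncc2c1N`), with cyclopentyl in place of cyclobutyl on an aromatic carbon. Among the measured compounds shown here, three measured steps bear on this change. The clearest is a 3.6-fold lower number from compound 1 to compound 3 (0.56 log units; beyond the scatter), with cyclobutyl in place of methyl. Next comes an at least 4.6-fold lower number from compound 2 to compound 3 (0.66 log units; beyond the scatter), which rests on a limit and so gives only a bound on the size. The third, an at least 1.2-fold higher number from compound 1 to compound 2 (0.10 log units; that floor lies within the scatter), shows no firm change. A fall in the number with a growing group is therefore only partly supported, and compound 2 goes against it.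

For the measured compounds named here, no measured step covers cyclopentyl itself, so the modest fall seen in a 3.6-fold lower number from compound 1 to compound 3 (0.56 log units; beyond the scatter) serves as the guide. A further fall of similar or smaller size is expected, and the estimated step is a 2.2-fold lower number from compound 3 to compound 4 (0.34 log units; beyond the scatter). The expected value for compound 4 is 100000 nM, with an estimated range from 30000 nM to 300000 nM.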

Compound 4, solubility: 89000 nM
Beside the measured number, compound 4's estimate is 1.1-fold (0.05 log units) above it; the measured number falls inside the stated range.
By their numbers in this assay, from the lowest: compound 4; then compound 3; then compound 1. At a limit, above all of these: compound 2.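

In this assay, replacing cyclobutyl with cyclopentyl on this aromatic carbon gives a 2.4-fold lower number from compound 3 to compound 4 (0.39 log units; beyond the scatter) and so extends the fall first seen with cyclobutyl to a second ring size. The full span from the methyl compound is an 8.8-fold lower number from compound 1 to compound 4 (0.94 log units; beyond the scatter) and places compound 4 lowest of the compounds shown, with the numbers falling in order through compound 1, compound 3 and compound 4 as the group on this carbon changes from methyl to cyclobutyl to cyclopentyl. Compound 2, which carries isopropyl, goes against this order and reports only a limit, so an at least 11-fold lower number from compound 2 to compound 4 (1.05 log units; beyond the scatter) gives a bound and not a size, as the evidence shows: the limit of > 1000000 nM in this assay, at which 1 of the 4 values shown sits.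

The compounds shown leave open whether the fall continues with a still larger ring such as cyclohexyl, or whether it would persist with a ring containing oxygen such as tetrahydropyranyl. They also leave open how far compound 2 really lies from the other compounds and why the open-chain isopropyl does not follow the order of the other three groups.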